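Amino acid ester variation on the hydrazide-linked core

The source may report more compounds than this note shows. Statements on the series, on what has been measured and on what is new or still open speak of the compounds shown alone.

Compound 1 `COc1cc(-c2nc3ccccc3s2)ccc1OCC(=O)NNC(=O)CN[C@@H](CS)C(=O)O` gives 3120 nM in a functional assay on HepG2 cells (Homo sapiens) for inhibition, read by MTT assay, with a stated time of 3 days (a higher number here means a weaker inhibitor, a lower number a stronger inhibitor), the lowest of the two numbers measured here. Compound 2 `CCOC(=O)[C@@H](NCC(=O)NNC(=O)COc1ccc(-c2nc3ccccc3s2)cc1OC)[C@@H](C)CC` gives 3460 nM in this assay. Compound 3 `CCOC(=O)[C@@H]1CCCN1CC(=O)NNC(=O)COc1ccc(-c2nc3ccccc3s2)cc1OC` differs from compound 1 in one place: 2-(ethoxycarbonyl)pyrrolidin-1-yl in place of (1-carboxy-2-sulfanylethyl)amino on a saturated chain carbon bound to a carbonyl carbon. Going by the values given here, the only step that bears on this, a 1.1-fold higher number from compound 1 to compound 2 (0.04 log units; within the scatter), also put an ethoxycarbonyl-bearing group in place of 1-carboxy-2-sulfanylethyl on an amine nitrogen and stayed within the scatter, so no step beyond the scatter is expected in this assay. Compound 3 is therefore estimated at 3300 nM, within 1500 nM to 7500 nM. The expected step is a 1.1-fold higher number from compound 1 to compound 3 (0.02 log units; within the scatter).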

Compound 3, half-maximal inhibitory concentration: 2800 nM
For compound 3 the middle estimate is 1.2-fold (0.07 log units) above the measured one, within the range that was stated.
By their numbers in this assay, from the lowest: compounds 3, 1 and 2 (each within the scatter of the next).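

In this assay, 2-(ethoxycarbonyl)pyrrolidin-1-yl on the saturated chain carbon bound to a carbonyl carbon gives a 1.1-fold lower number from compound 1 to compound 3 (0.05 log units; within the scatter) and a 1.2-fold lower number from compound 2 to compound 3 (0.09 log units; within the scatter). The place therefore takes a five-membered non-aromatic ring with no hydrogen-bond donors in the entering group, and the number stays within the scatter of both open-chain amino groups. No supporting data explain this flat result. Still open, as far as these compounds go, is whether a free carboxylic acid on the pyrrolidine ring, in place of the ethoxycarbonyl group, would keep the number within the scatter. From the compounds shown here alone, a piperidine ring at this place is equally open.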